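The source may hold more compounds than are shown below. What is called first, only, known or untested is meant among the compounds shown, and "the series" means these compounds.

In a functional assay on HCT-116 cells (Homo sapiens) for inhibition (a higher number here means a weaker inhibitor, a lower number a stronger inhibitor), compound 1 `C/C=C/C(=O)OCc1cc(=O)oc2cc(OC)c(OC)cc12` is reported only as a limit, > 10 ug/mL. Among the measured compounds shown here, compound 2 `COc1cc2oc(=O)cc(COC(=O)/C=C/c3ccc(O)cc3)c2cc1OC` gives 5.21 ug/mL, and so far it is the only compound in this small set with an actual number. For the measured compounds named here, the one measured step, an at least 1.9-fold lower number from compound 1 to compound 2 (0.28 log units; that floor lies within the scatter), puts 4-hydroxyphenyl in place of methyl on a double-bonded chain carbon bound to a double-bonded chain carbon. That step is bounded on one side only, by the limit of > 10 ug/mL in this assay, at which 1 of the 2 values shown sits.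

Compound 3 `COc1ccc(/C=C/C(=O)OCc2cc(=O)oc3cc(OC)c(OC)cc23)cc1O` keeps the shared core and changes the same place again, the difference from compound 2 being (3-hydroxy-4-methoxyphenyl in place of 4-hydroxyphenyl on a double-bonded chain carbon bound to a double-bonded chain carbon). The ring stays a six-membered aromatic ring of carbon only, and a single hydrogen-bond donor remains. The measured step from compound 1 exchanged methyl for a ring, whereas this one only alters the ring, so an at least 1.9-fold lower number from compound 1 to compound 2 (0.28 log units; that floor lies within the scatter) gives little guidance on its size. No shift beyond the scatter is therefore expected in this assay, in either direction. For compound 3 the estimated step is a 1.0-fold lower number from compound 2 to compound 3 (0.02 log units; within the scatter). Compound 3 is expected at 5 ug/mL, within an estimated range of 2.2 ug/mL to 10 ug/mL.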

Compound 3, half-maximal inhibitory concentration: 3.41 ug/mL
Estimate against measurement, compound 3: 1.5-fold (0.17 log units) above, within the range that was stated.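

In this assay, among the compounds shown here, the series now holds an at least 2.9-fold lower number from compound 1 to compound 3 (0.46 log units; beyond the scatter), and this is the first exchange of methyl for a substituted ring on a double-bonded chain carbon bound to a double-bonded chain carbon that clears the scatter, which the earlier step to compound 2 did not do. Changing the ring itself gives a 1.5-fold lower number from compound 2 to compound 3 (0.18 log units; within the scatter), so 4-hydroxyphenyl and 3-hydroxy-4-methoxyphenyl cannot be told apart in this assay, and the added methoxy group leaves no readable mark at this place. The larger step remains bounded on one side only, as compound 1 is reported as a limit and not as a number: the limit of > 10 ug/mL in this assay, at which 1 of the 3 values shown sits.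

As far as these compounds go, what stays open is whether the ring alone carries the step from methyl or whether its hydroxyl is also needed, a question that an unsubstituted phenyl, or a ring bearing an amine or a carboxylic acid, would address. Also open, from the compounds shown here alone, is how a saturated chain in place of the two double-bonded chain carbons would read in this assay.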